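The compounds below may be only part of what the source reports. "The series", "measured", "known", "first", "only" and "open" are said of these compounds alone.

The measured compounds are compound 1 `CCOC(=O)/C=C(C)/C=C/CC(C)CCCC(C)(C)OC` with 5.54 in a physicochemical assay for lipophilicity (a higher number here means a more lipophilic compound, a lower number a more polar compound), compound 2 `CCOC(=O)/C=C(C)/C=C/CC(C)CCCC(C)(C)O` with 4.65, and compound 3 `CCOC(=O)/C=C(C)/C=C/CC(C)CCC(=O)C(C)C` with 4.3.

Compound 1 gives the highest of the three numbers in this assay. Its nearest neighbour is compound 2, reached by a number 0.89 log units lower from compound 1 to compound 2 (beyond the scatter), and its furthest is compound 3, reached by a number 1.24 log units lower from compound 1 to compound 3 (beyond the scatter). Between the other two, the difference is a number 0.35 log units lower from compound 2 to compound 3 (beyond the scatter).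

Compound 4 `COC(C)(C)CCCC(C)C/C=C/C(C)=C/C(N)=O` is not yet measured. It differs from compound 1 at the carbonyl carbon: amino in place of ethoxy on a carbonyl carbon. For the measured compounds named here, none of the measured steps touches this carbonyl carbon, so no step bears on it directly. The closest comparison is the step from compound 1 to compound 2, where one hydrogen-bond donor enters and a methyl leaves, giving a number 0.89 log units lower from compound 1 to compound 2 (beyond the scatter). The change to compound 4 removes an acceptor-bearing ethoxy and brings in a donor-bearing amino, a change of a different kind at a different place, and a larger drop than that step is therefore expected, in the direction of lower numbers and beyond the scatter. For compound 4 the expected value in this assay is 3.7, within 3.1 to 4.3, meaning an estimated step of a number 1.84 log units lower from compound 1 to compound 4 (beyond the scatter).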

Compound 4, partition coefficient: 3.52
Beside the measured number, compound 4's estimate is 0.18 log units above it, within the range that was stated.
By their numbers in this assay, from the lowest: compound 4; then compound 3; then compound 2; then compound 1.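

For the compounds shown here, the carbonyl carbon, untouched by the earlier steps, proves to be a place where a single change moves the number in this assay a long way: amino in place of ethoxy gives a number 2.02 log units lower from compound 1 to compound 4 (beyond the scatter). This is larger than either earlier step from compound 1, a number 0.89 log units lower from compound 1 to compound 2 (beyond the scatter) and a number 1.24 log units lower from compound 1 to compound 3 (beyond the scatter), although those changes were made elsewhere on the chain, and compound 4 keeps the rest of compound 1 unchanged, so its step can be read at this one place. In this change an ethoxy of three heavy atoms with one hydrogen-bond acceptor leaves, and an amino of one heavy atom with one hydrogen-bond donor enters, but nothing measured explains why the number falls by this amount.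

The compounds shown do not separate the loss of the ethoxy from the arrival of the amino, a question that methoxy, methylamino or dimethylamino on the same carbonyl carbon would address. They also leave open whether the same exchange would give a step of similar size on compound 2 or compound 3, and how a carboxylic acid at this carbonyl carbon would compare.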